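The compounds below may be only part of what the source reports. "The series", "measured", "known", "first", "only" and "open" are said of these compounds alone.

Measured compounds:
compound 1, `COc1cccc(/C=C/c2cc3c(c(=O)n(C)c(=O)n3C)n2C)c1`, 370 nM in an assay on isolated protein for inhibition of Amine oxidase [flavin-containing] B (Homo sapiens), read by luminescence, with a stated time of 1 h; a lower number here means a stronger inhibitor, a higher number a weaker inhibitor
compound 2, `Cn1c(=O)c2c(cc(Oc3cccc(Cl)c3)n2C)n(C)c1=O`, > 10000 nM in this assay

In this assay compound 1 gives 370 nM. Compound 2 reaches only a limit of the assay, > 10000 nM, so no number is known for it. Its position is set by the limit of > 10000 nM in this assay, at which 1 of the 2 values shown sits. Compound 3, `Cn1c(=O)c2c(cc(Oc3cccc(-c4ccccc4)c3)n2C)n(C)c1=O`, differs from compound 2 by phenyl in place of chloro on an aromatic carbon, in words phenyl in place of chloro on an aromatic carbon. Within the data shown here, no measured pair shows this change, so the size of the step is open. Because compound 2 sits at > 10000 nM, only a move toward stronger inhibition could be seen at all; a move the other way or none beyond the scatter would leave compound 3 at a limit as well. Compound 3 is expected near 8000 nM, with a range from 1500 nM to 30000 nM. This estimate corresponds to an expected step of an at least 1.2-fold lower number from compound 2 to compound 3 (0.09 log units; that floor lies within the scatter).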

Compound 3, half-maximal inhibitory concentration: > 10000 nM
Compound 3 ended at the assay's limit; the forecaster's own chance of this, stated with the estimate: 55%; at least 1.2-fold (0.09 log units) between middle value and limit.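

No step can be read from compound 2 to compound 3, because both stop at a limit of the assay and not at a number: the limit of > 10000 nM in this assay, at which 2 of the 3 values shown sit. The compounds shown leave open whether phenyl in place of chloro on an aromatic carbon changes inhibition at all.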